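The source may hold more compounds than are shown below. What is called first, only, known or untested is meant among the compounds shown, and "the series" means these compounds.

Measured so far:
- compound 1 `C=CCOc1ccc(C(=O)Nc2cccc(CC)n2)cc1`: 27400 nM
- compound 2 `CCCOc1ccc(C(=O)Nc2cnccn2)cc1`: 22500 nM
- compound 3 `CCCOc1ccc(C(=O)Nc2cccc(CC)n2)cc1`: 29200 nM

All three were tested in an in vitro assay on HEK-tsA201 cells for antagonist activity at Neuronal acetylcholine receptor; alpha3/beta4 (Homo sapiens), read by fluorescence and calcium flux; on this read-out lower numbers stand for stronger inhibition and higher numbers for weaker inhibition. The numbers sit close together: compound 3 gives a value that lies within the usual scatter of both compound 1 and compound 2, so none of the three can be set apart from the others on this evidence.

For the measured compounds named here, only one pair differs in a single place. From compound 1 to compound 3 the chain on the oxygen changes, and the result is a 1.1-fold higher number from compound 1 to compound 3 (0.03 log units; within the scatter), a shift too small to count.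

Compound 4 `CCCOc1ccc(C(=O)Nc2cccc(Nc3cccc(F)c3)n2)cc1` is not yet measured. It differs from compound 3 on the ring that carries the amide: (3-fluorophenyl)amino in place of ethyl on an aromatic carbon. Going by the values given here, no measured step touches this part of the shared core; the one known step concerns the chain on the oxygen, and compound 2 differs from compound 3 in the ring itself, not in a single group, so its value only shows that a change of ring left the number in the same region.

Among the compounds with values here, with no step of the same kind in hand, the outcome is open. Compound 4 is therefore estimated at 15000 nM, with a range from 3000 nM to 70000 nM. The step this estimate implies, a 1.9-fold lower number from compound 3 to compound 4 (0.29 log units; within the scatter), is an expectation only.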

Compound 4, half-maximal inhibitory concentration: > 100000 nM
Compound 4 gave a limit, no number (the forecaster's own chance of this, stated with the estimate: 25%); middle value at least 6.6-fold (0.82 log units) from the limit.
By their numbers in this assay, from the lowest: compounds 2, 1 and 3 (each within the scatter of the next). At a limit, above all of these: compound 4.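

The earlier compounds shown here showed only a change in the chain on the oxygen, which could not be told from scatter. For the compounds shown here, compound 4 is the first to change the aromatic carbon next to the ring nitrogen, and the result moves beyond the scatter: in this assay, (3-fluorophenyl)amino in place of ethyl gives an at least 3.4-fold higher number from compound 3 to compound 4 (0.53 log units; beyond the scatter). This position is therefore not indifferent to what it carries, and here the larger group, with its added aromatic ring and hydrogen-bond donor, goes with weaker inhibition. Only a lower bound on the step can be stated because compound 4 gave a limit rather than a number: the limit of > 100000 nM in this assay, at which 1 of the 4 values shown sits.

On these data alone, this single swap cannot separate the parts of the entering group, so the roles of the added ring, the linking nitrogen and the fluorine remain open; a plain amine or an unsubstituted phenylamino group at this carbon would begin to pull them apart. Also open, as far as these compounds go, is whether any group here, such as methyl or methoxy, could give stronger inhibition than ethyl does.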